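Methyl to ethyl on the ring amide nitrogen of compound 2

The compounds below may be only part of what the source reports. "The series", "measured", "known", "first", "only" and "open" are said of these compounds alone.

Compound 1 `O=C1CN(C2CCCC2)c2nc(Nc3ccc(N4CCCCC4)cc3)ncc2N1` gives in a functional assay on HeLa cells (Homo sapiens) for inhibition, read by MTT assay, with a stated time of 48 h (a lower number here means a stronger inhibitor, a higher number a weaker inhibitor), only a limit, > 30000 nM.
Compound 2 `CN1C(=O)CN(C2CCCC2)c2nc(Nc3ccc(N4CCCCC4)cc3)ncc21` gives in this assay 16900 nM.
Compound 3 `CC1CCN(c2ccc(Nc3ncc4c(n3)N(C3CCCC3)CC(=O)N4C)cc2)CC1` gives in this assay only a limit, > 30000 nM.

Compound 2 holds the only number shown; the other two values are limits. Compound 4 `CCN1C(=O)CN(C2CCCC2)c2nc(Nc3ccc(N4CCCCC4)cc3)ncc21` differs from compound 2 by methyl in place of hydrogen on a saturated chain carbon bound to an amide-type nitrogen in a ring. Going by the values given here, two measured steps touch this series: an at least 1.7-fold lower number from compound 1 to compound 2 (0.24 log units; that floor lies within the scatter) and an at least 1.7-fold higher number from compound 2 to compound 3 (0.24 log units; that floor lies within the scatter); both rest on the limit of > 30000 nM in this assay, at which 2 of the 3 values shown sit, and stay within the scatter. Neither step adds a carbon to an existing methyl, so they give no direct guide, and no step beyond the scatter is expected in this assay for compound 4. Compound 4 is therefore estimated at 15000 nM, between 5000 nM and 45000 nM, a step of a 1.1-fold lower number from compound 2 to compound 4 (0.05 log units; within the scatter) that is expected to remain within the scatter.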

Compound 4, half-maximal inhibitory concentration: > 30000 nM
Compound 4: a limit, no number; the forecaster's own chance of this, stated with the estimate: 30%; middle value at least 2.0-fold (0.30 log units) away from the limit.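

In this assay, methyl to ethyl on the ring amide nitrogen gives an at least 1.7-fold higher number from compound 2 to compound 4 (0.24 log units; that floor lies within the scatter), so this first change to the methyl itself shows no shift beyond the scatter. Compound 4 gives a limit, > 30000 nM, and the step that links it to compound 1 cannot be read, since both values are limits. Compound 2 is now the only compound in the series with a number: the limit of > 30000 nM in this assay, at which 3 of the 4 values shown sit.

The compounds shown leave open whether a propyl chain, or a chain ending in an amine, on this nitrogen would give a number rather than a limit. They also leave open how far compound 4 truly lies from compound 2.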